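2,6-Dimethoxyphenyl to 2,4-dichlorophenyl: compound 2 towards compound 3

The compounds below may be only part of what the source reports. "The series", "measured", "known", "first", "only" and "open" are said of these compounds alone.

For the measured compounds named here, in a functional assay on Hs-578T cells (Homo sapiens) for inhibition, read by sulforhodamine B assay, with a stated time of 48 h (on this read-out higher numbers stand for weaker inhibition of growth and lower numbers for stronger inhibition of growth), compound 1 `O=C(Cc1csc2nc(-c3ccc(Br)cc3)cn12)N/N=C/c1ccc(O)cc1` gives 23400 nM, and compound 2 `COc1cccc(OC)c1/C=N/NC(=O)Cc1csc2nc(-c3ccc(Br)cc3)cn12` gives 11500 nM, the lower of the two numbers so far. Compound 3 `O=C(Cc1csc2nc(-c3ccc(Br)cc3)cn12)N/N=C/c1ccc(Cl)cc1Cl` carries 2,4-dichlorophenyl in place of 2,6-dimethoxyphenyl on a carbon with a double bond to nitrogen. Going by the values given here, one measured step bears on this change, made at the same place: a 2.0-fold lower number from compound 1 to compound 2 (0.31 log units; beyond the scatter), a modest step beyond the scatter. Among the compounds with values here, no measured compound carries a 2,4-dichlorophenyl group, so the data set no direction for the new step. In this assay, a step of similar modest size or none beyond the scatter is therefore expected, with only a slight lean towards a lower number. The estimate corresponds to a 1.2-fold lower number from compound 2 to compound 3 (0.06 log units; within the scatter). The estimated value for compound 3 is 10000 nM, with an expected range of 3500 nM to 30000 nM.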

Compound 3, concentration for 50% growth inhibition: 31600 nM
Compound 3: the middle estimate sits 3.2-fold (0.50 log units) below what was measured; the whole stated range lies below it.
By their numbers in this assay, from the lowest: compound 2; then compounds 1 and 3 (each within the scatter of the next).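

In this assay the change to 2,4-dichlorophenyl gives a 2.7-fold higher number from compound 2 to compound 3 (0.44 log units; beyond the scatter), so steps at this place on a carbon with a double bond to nitrogen now run in both directions. Set against 4-hydroxyphenyl, the same group gives a 1.4-fold higher number from compound 1 to compound 3 (0.13 log units; within the scatter), so these two groups do not separate, and among the three groups only 2,6-dimethoxyphenyl stands apart, beyond the scatter from both. No measurement available here offers an explanation for this pattern.

On these data alone, it remains open whether a single methoxy group, an unsubstituted phenyl, or a phenyl carrying an amine or a carboxylic acid would match compound 2, which gives 11500 nM. As far as these compounds go, it also remains open whether any group at this place can reach a clearly lower number than compound 2.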